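The source may hold more compounds than are shown below. What is called first, only, known or untested is meant among the compounds shown, and "the series" means these compounds.

Measured compounds:
- compound 1, `Oc1ccc(-c2cc(-c3ccc(Cl)cc3)nc(-c3cccnc3)c2)cc1`, "not determined" (no result reported) in an assay on isolated protein for inhibition of DNA topoisomerase 1 (Homo sapiens), with a stated time of 30 min, tested at 20 uM; on this read-out lower numbers stand for a weaker effect and higher numbers for a stronger effect at the one concentration tested
- compound 2, `Oc1ccc(-c2cc(-c3ccc(Cl)cc3)nc(-c3cccs3)c2)cc1`, 0%

Among the measured compounds shown here, compound 2 is the only compound here with a number in this assay. Compound 1 carries no result there, so nothing can be said about how compound 1 and compound 2 compare. Compound 2 itself shows no measurable effect at the single concentration tested, since it gives 0%.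

Compound 3, `Oc1ccc(-c2cc(-c3ccc(Cl)cc3)nc(-c3ccsc3)c2)cc1`, has not yet been tested. It has the same atoms as compound 2, joined differently: thiophen-3-yl in place of thiophen-2-yl on an aromatic carbon. The five-membered ring keeps its single sulfur and its count of carbons; only the point at which it attaches to the rest of the molecule moves.

For the measured compounds named here, no step between two measured compounds is available to guide an expectation, so the only anchor is compound 2 at 0%. With a change of this small size, and with the starting point already at the bottom of the scale, the step from compound 2 to compound 3 is expected to stay within the usual scatter, which is what a number 3 percentage points higher from compound 2 to compound 3 (within the scatter) means here. Compound 3 is therefore estimated at 3%, with a range from 0% to 15%.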

Compound 3, a percentage reported as inhibition, at one concentration (the size of the read-out at that concentration, not a potency): 30.7%
Compound 3: middle estimate off by 27.7 percentage points, on the low side; measured number outside the range, above it.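

In this assay, moving the attachment point of the five-membered ring, with thiophen-3-yl in place of thiophen-2-yl, gives a number 30.7 percentage points higher from compound 2 to compound 3 (beyond the scatter). This shows that the position on the aromatic carbon next to the ring nitrogen is sensitive to how this ring is joined: the two groups have the same atoms and the same counts of hydrogen-bond donors and acceptors, so these counts alone do not separate compound 2 from compound 3. No measurement here explains why the point of attachment matters so much.

The compounds shown leave open whether the effect depends on the sulfur-containing ring itself, since a furan-3-yl group or a plain phenyl group at this position would be needed to test that, and compound 1, at "not determined" (no result reported), gives no help. They also leave open how compound 3 behaves at other concentrations, since a single-concentration read-out is not a potency, and whether a change elsewhere on the shared core, such as an amine in place of the hydroxyl group, would alter the effect.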